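Furan-3-yl to thiophen-2-yl on a shared core

The source may report more compounds than this note shows. Statements on the series, on what has been measured and on what is new or still open speak of the compounds shown alone.

In a functional assay on K562 cells (Homo sapiens), read by MTT assay, with a stated time of 72 h (on this read-out lower numbers stand for stronger inhibition and higher numbers for weaker inhibition), compound 3 (`Cc1nc(N)c2c(-c3ccoc3)cn([C@@H]3O[C@H](CO)[C@@H](O)[C@H]3O)c2n1`) gives > 20000 nM, which is a limit of the assay and not a number. Compound 2 (`Cc1nc(N)c2c(-c3ccco3)cn([C@@H]3O[C@H](CO)[C@@H](O)[C@H]3O)c2n1`) gives > 20000 nM, again a limit. Compound 1 (`Nc1nc(N)c2c(-c3cccs3)cn([C@@H]3O[C@H](CO)[C@@H](O)[C@H]3O)c2n1`), which already carries thiophen-2-yl, gives > 20000 nM, also a limit, and this is the nearest ground for the expectation below. Every reading so far thus ends at the limit of > 20000 nM in this assay, at which 3 of the 3 values shown sit, and no order can be drawn among these compounds.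

The next structure is compound 4 (`Cc1nc(N)c2c(-c3cccs3)cn([C@@H]3O[C@H](CO)[C@@H](O)[C@H]3O)c2n1`). It has thiophen-2-yl in place of furan-3-yl on an aromatic carbon.

Among the measured compounds shown here, the one measured step that bears on this exchange is a step that the two limits leave unreadable from compound 2 to compound 3, a swap of furan-2-yl for furan-3-yl on that same aromatic carbon. It offers no size to carry over, so no step beyond the scatter is expected in this assay, and no direction can be given. The expected outcome is a number no higher from compound 3 to compound 4 (the limit leaves the size open). For compound 4 the estimate is 20000 nM, with an expected range from 7000 nM to 30000 nM. The likeliest report is once more only a limit.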

Compound 4, half-maximal inhibitory concentration: > 20000 nM
Compound 4: a limit, no number; the forecaster's own chance of this, stated with the estimate: 85%; the middle value sits exactly at the limit.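

In this assay compound 4 gives > 20000 nM, which is a limit of the assay and not a number. The steps to compound 4 from compound 1, compound 2 and compound 3 therefore cannot be read. The compounds shown leave open any order among them on the shared core, as every reading ends at the same point: the limit of > 20000 nM in this assay, at which 4 of the 4 values shown sit.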